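Bromo to chloro on the pendant aryl ring

A few compounds are considered here, and "the series" means these few. Any claim that something is new, unique, unknown or untested is made for them only; others in the source may bear on it.

Compound 1 `O=c1c2ccccc2[se]n1-c1nnc(-c2ccc(Br)cc2)s1` gives 43300 nM in a functional assay on MCF7 cells (Homo sapiens) for antiproliferative activity, read by CCK-8 assay, with a stated time of 48 h (on this read-out lower numbers stand for stronger inhibition and higher numbers for weaker inhibition), the highest of the two numbers recorded so far. Compound 2 `O=c1c2ccccc2[se]n1-c1nnc(-c2cccc([N+](=O)[O-])c2)s1` gives 29200 nM, and the two values lie within the scatter of each other, so no order between them is claimed. Compound 3 `O=c1c2ccccc2[se]n1-c1nnc(-c2ccc(Cl)cc2)s1` carries the change (chloro in place of bromo on an aromatic carbon), chloro in place of bromo on an aromatic carbon, para to a large group. For the measured compounds named here, no measured pair shows this change; its step is expected to be small, a 1.0-fold higher number from compound 1 to compound 3 (0.02 log units; within the scatter), within the scatter in either direction. Compound 3 is therefore expected near 45000 nM, between 20000 nM and 100000 nM.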

Compound 3, half-maximal inhibitory concentration: 19500 nM
Estimate against measurement, compound 3: 2.3-fold (0.36 log units) above; the measured number lies below the stated range.
By their numbers in this assay, from the lowest: compounds 3, 2 and 1 (each within the scatter of the next, the first and the last beyond it).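

In this assay, for the compounds shown here, the change from 4-bromophenyl to 4-chlorophenyl gives a 2.2-fold lower number from compound 1 to compound 3 (0.35 log units; beyond the scatter) and is the only single-place step so far. The read-out at this position, on an aromatic carbon para to a large group, therefore differs modestly between these two halogens. No available evidence accounts for this step.

Going by these compounds, it remains open whether the trend extends to fluoro at this position or whether an amine or a carboxylic acid there would move the number further. Going by these compounds alone, compound 3 is also the only chloro compound, so this single step cannot show whether the same change would behave alike elsewhere on the ring.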